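The compounds below may be only part of what the source reports. "The series", "measured", "known", "first", "only" and "open" are said of these compounds alone.

Working notes on the series. Within the data shown here, compound 1 `CC(=O)N1N=C(c2ccc3ccccc3c2)OC1c1cccc(F)c1` is the weaker of the two compounds measured so far in a functional assay on HepG2 cells (Homo sapiens) for antiproliferative activity, read by MTT assay, with a stated time of 48 h; a lower number here means a stronger inhibitor, a higher number a weaker inhibitor: compound 1 gives 1.86 ug/mL, which is the highest of the two numbers at hand. Its nearest neighbour is compound 2 `CC(=O)N1N=C(c2ccc3ccccc3c2)OC1c1ccc2ccccc2c1`, which in this assay gives 0.85 ug/mL, a lower number than that of compound 1, and the gap between the two lies beyond the usual scatter. Among the measured compounds shown here, no single-point step between measured compounds is available, so nothing more than these two values can be read from the pair.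

Compound 3 `CC(=O)N1N=C(c2ccc3ccccc3c2)OC1c1ccsc1` has not yet been measured in this assay. It differs from compound 1 in one place: thiophen-3-yl in place of 3-fluorophenyl on a saturated ring carbon. For the measured compounds named here, with only compound 1 as a direct reference point, and no measured step to lean on, the expected change from compound 1 to compound 3 in this assay is a 1.3-fold higher number from compound 1 to compound 3 (0.13 log units; within the scatter), that is, no shift that would clearly stand out beyond the scatter, if anything a slightly higher number. Compound 3 is therefore estimated at 2.5 ug/mL, with a range of 1 ug/mL to 6 ug/mL.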

Compound 3, half-maximal inhibitory concentration: 6.82 ug/mL
For compound 3 the middle estimate is 2.7-fold (0.44 log units) below the measured one; measured number above the stated range.
By their numbers in this assay, from the lowest: compound 2; then compound 1; then compound 3.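

In this assay, thiophen-3-yl and 3-fluorophenyl are not interchangeable on this saturated ring carbon, next to the ring oxygen: the exchange gives a 3.7-fold higher number from compound 1 to compound 3 (0.56 log units; beyond the scatter). Among these compounds, this is the first single-place step measured at this position, and it shows that the group here can shift the number beyond the scatter, with the five-membered aromatic ring on the weaker side of the six-membered aromatic ring of carbon only. No measurement at hand bears on the reason for this shift.

The compounds shown leave open whether the higher number goes with the smaller ring, with the sulfur or with the loss of fluorine, as this one step changes all three at once. Also open, as far as these compounds go, is how an unsubstituted phenyl, a pyridyl ring or a phenyl carrying an amine would read on this carbon, and how a longer acyl chain would read in place of the acetyl group on the shared core.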